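The source may hold more compounds than are shown below. What is called first, only, known or untested is meant among the compounds shown, and "the series" means these compounds.

Measured so far in a functional assay on HL-60 cells (Homo sapiens) for inhibition, read by CCK-8 assay, with a stated time of 48 h; a lower number here means a stronger inhibitor, a higher number a weaker inhibitor:
compound 1 `O=C(NCCNS(=O)(=O)c1ccc(-c2ccccc2O[C@H]2CC[C@H](O)CC2)s1)Nc1cc(C(F)(F)F)cc(C(F)(F)F)c1` gives 7100 nM
compound 2 `COc1ccc(Oc2ccccc2-c2ccsc2S(=O)(=O)N2CCN(C(=O)Nc3cccc([N+](=O)[O-])c3)CC2)cc1OC` gives > 50000 nM as a limit

Among the compounds with values here, compound 1 at 7100 nM holds the only actual number so far. Compound 2 reads > 50000 nM as a limit of the assay and not as a number.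

Compound 3 `Nc1ccc(Oc2ccccc2-c2ccc(S(=O)(=O)NCCNC(=O)Nc3cc(C(F)(F)F)cc(C(F)(F)F)c3)s2)cc1` is still unmeasured. It differs from compound 1 by 4-aminophenyl in place of 4-hydroxycyclohexyl on an oxygen on an aromatic ring, the counted difference being 4-aminophenyl in place of 4-hydroxycyclohexyl on an oxygen on an aromatic ring and the rest of the structure unchanged.

Within the data shown here, no measured pair sizes such a change. In this assay no step beyond the scatter is therefore expected, and the estimated step of a 1.4-fold lower number from compound 1 to compound 3 (0.15 log units; within the scatter) stays within it. For compound 3 the expected value is 5000 nM and 1200 nM to 25000 nM is the estimated range.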

Compound 3, half-maximal inhibitory concentration: > 50000 nM
Compound 3: no number, only a limit; the forecaster's own chance of this, stated with the estimate: 10%; middle value at least 10-fold (1.00 log units) from the limit.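

In this assay, within the data shown here, the change from (4-hydroxycyclohexyl)oxy to 4-aminophenoxy gives the first step that can be read: an at least 7.0-fold higher number from compound 1 to compound 3 (0.84 log units; beyond the scatter). Compound 3 reads > 50000 nM, which is a limit of the assay and not a number. The group on this oxygen therefore matters, since with the rest of the structure unchanged compound 1 keeps a measured value and compound 3 does not, while the full size of the step stays unknown: the limit of > 50000 nM in this assay, at which 2 of the 3 values shown sit.

The exchange alters the ring and its substituent together, so the compounds shown do not tell which of the two carries the step. A 4-aminocyclohexyl group or a 4-hydroxyphenyl group on the same oxygen would separate these two changes.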